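Changing the group on sulfur in the series

The source may hold more compounds than are shown below. What is called first, only, known or untested is meant among the compounds shown, and "the series" means these compounds.

The measured compounds share one core and differ in the group on a sulfur. In a functional assay on SMMC-7721 cells (Homo sapiens) for inhibition, read by CCK-8 assay, with a stated time of 72 h, tested at 8 uM (a lower number here means less inhibition of growth, a higher number more inhibition of growth at the concentration tested), compound 1 (`Cc1cc(C)cc(SCc2ccc(/C=C/C(=O)Nc3ccccc3N)cc2)c1`) gives 7.13% of inhibition, compound 2 (`Nc1ccccc1NC(=O)/C=C/c1ccc(CSc2ccc(Cl)cc2)cc1`) gives 16.5% of inhibition and compound 3 (`CCc1ccc(SCc2ccc(/C=C/C(=O)Nc3ccccc3N)cc2)cc1`) gives 19.5% of inhibition. Compound 3 shares the upper end of this small range with one neighbour and stands apart from the other: the data show a number 3 percentage points higher from compound 2 to compound 3 (within the scatter) and a number 12.4 percentage points higher from compound 1 to compound 3 (beyond the scatter) on the same scale.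

Compound 4 (`Nc1ccccc1NC(=O)/C=C/c1ccc(CSc2cccc3ccccc23)cc1`) carries naphthalen-1-yl in place of 4-ethylphenyl on a sulfur and keeps the rest of the core. All three measured steps are swaps at this sulfur. Besides the two above, the data show a number 9.4 percentage points higher from compound 1 to compound 2 (within the scatter) as the remaining one. The largest of them is modest, and none carries naphthalen-1-yl, so the data fix no direction for this change. No step beyond the scatter is therefore expected in this assay for this swap. The expected step is a number 4.5 percentage points lower from compound 3 to compound 4 (within the scatter) by this estimate. Compound 4 is estimated at 15% with an expected range from 5% to 30% in this read-out.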

Compound 4, percent growth inhibition at one concentration: 18.3%
Compound 4: the middle estimate sits 3.3 percentage points below what was measured; low and high end bracket the measured number.
By their numbers in this assay, from the lowest: compounds 1, 2, 4 and 3 (each within the scatter of the next, the first and the last beyond it).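

In this assay, naphthalen-1-yl, with two six-membered aromatic rings of carbon only, replaces the single ring of 4-ethylphenyl in a number 1.2 percentage points lower from compound 3 to compound 4 (within the scatter) and that of 4-chlorophenyl in a number 1.8 percentage points higher from compound 2 to compound 4 (within the scatter) on this sulfur, so the larger group, with 10 heavy atoms, gives a number that cannot be told apart from those of compound 2 and compound 3. The swap from 3,5-dimethylphenyl gives a number 11.2 percentage points higher from compound 1 to compound 4 (beyond the scatter) and is the second modest step beyond the scatter at this position, although compound 2 remains within the scatter of compound 1, so the series does not divide cleanly into two groups. No supporting data bear on what lies behind these steps.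

From the compounds shown here alone, all four groups on sulfur are aromatic rings of carbon only, so it remains open how a ring carrying an amine or a carboxylic acid, a saturated cyclohexyl group or a longer alkyl chain would behave here. Going by these compounds, whether naphthalen-2-yl matches naphthalen-1-yl also remains open, as does how these compounds compare at any other concentration.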